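A few compounds are considered here, and "the series" means these few. Any claim that something is new, unique, unknown or untested is made for them only; others in the source may bear on it.

Measured so far:
- compound 1, `COc1ccc(OC)c(-c2cn(-c3ccc(O)c(C(=O)OCCCc4ccccc4)c3)nn2)c1`, giving 13% in a functional assay on HCT-116 cells (Homo sapiens) for inhibition, read by MTT assay, with a stated time of 2 days, tested at 10 uM; on this read-out lower numbers stand for less inhibition and higher numbers for more inhibition at the one concentration tested (going by the name of the read-out)
- compound 2, `COc1cc(OC)cc(-c2cn(-c3ccc(O)c(C(=O)OCCCc4ccccc4)c3)nn2)c1`, giving 19% in this assay
- compound 3, `COC(=O)c1cc(-n2cc(-c3cccc(O)c3)nn2)ccc1O`, giving 6% in this assay

Compound 3 stands at the lowest of the three numbers, but its gap to compound 1 lies within the scatter, and only its gap to compound 2 lies beyond it. Among the measured compounds shown here, the one measured step, a number 6 percentage points higher from compound 1 to compound 2 (within the scatter), concerns a change elsewhere in the molecule and stays within the scatter.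

Compound 4, `O=C(OCCCc1ccccc1)c1cc(-n2cc(-c3cccc(O)c3)nn2)ccc1O`, differs from compound 3 in one place: phenethyl in place of hydrogen on a saturated chain carbon bound to an oxygen next to a carbonyl group. Cut one bond further out, the same difference reads methyl to 3-phenylpropyl, or methoxy to 3-phenylpropoxy. For the measured compounds named here, no measured pair isolates this change: compound 1 and compound 2 carry the 3-phenylpropoxy ester, yet they differ from compound 3 in another ring as well, so their numbers show only that this ester is compatible with values near those of compound 3 in this assay. Going by the values given here, with no step to lean on, the expectation is a step of a number 6 percentage points higher from compound 3 to compound 4 (within the scatter), not beyond the scatter. Compound 4 is therefore estimated at 12% in this assay, with a range from 0% to 30%.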

Compound 4, a percentage reported as inhibition, at one concentration (the size of the read-out at that concentration, not a potency): 11%
Beside the measured number, compound 4's estimate is 1 percentage points above it; low and high end bracket the measured number.
By their numbers in this assay, from the lowest: compounds 3, 4, 1 and 2 (each within the scatter of the next, the first and the last beyond it).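

Among the compounds shown here, the pair of compound 3 and compound 4 isolates the ester for the first time: in this assay, going from methyl to 3-phenylpropyl gives a number 5 percentage points higher from compound 3 to compound 4 (within the scatter), so adding phenethyl in place of hydrogen on this saturated chain carbon bound to an oxygen next to a carbonyl group brings no step beyond the scatter. With the 3-phenylpropoxy ester held constant, the other ring can now be read as well: 3-hydroxyphenyl in place of 3,5-dimethoxyphenyl gives a number 8 percentage points lower from compound 2 to compound 4 (within the scatter), and 3-hydroxyphenyl in place of 2,5-dimethoxyphenyl gives a number 2 percentage points lower from compound 1 to compound 4 (within the scatter), so neither swap separates the compounds beyond the scatter. No independent measurement is available to explain these numbers.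

Still open, as far as these compounds go, is whether a carboxylic acid or an amide in place of the ester, or a chain shorter or longer than 3-phenylpropyl, would produce a step beyond the scatter. Also open, from the compounds shown here alone, is whether an amine on the aromatic ring would do so, and whether any of these steps would look the same at a concentration other than the single one tested.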